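The compounds below may be only part of what the source reports. "The series", "measured", "known", "first", "only" and "open" are said of these compounds alone.

Among the compounds with values here, compound 2 `COC(=O)c1ccc(C2SCC(=O)N2c2ccc(N3CCN(S(=O)(=O)c4ccc(F)cc4)CC3)cn2)c(OC)c1` gives 78300 nM in a functional assay on Jurkat cells (Homo sapiens) for antiproliferative activity, read by MTT assay and trypan blue exclusion, with a stated time of 72 h (on this read-out higher numbers stand for weaker inhibition and lower numbers for stronger inhibition), the higher of the two numbers known, while compound 1 `COC(=O)c1ccc(C2SCC(=O)N2c2ccc(N3CCN(Cc4cccc([N+](=O)[O-])c4)CC3)cn2)c(OC)c1` gives 37400 nM. Within the data shown here, the only measured step, a 2.1-fold higher number from compound 1 to compound 2 (0.32 log units; beyond the scatter), joins these two. Compound 3 `COC(=O)c1ccc(C2SCC(=O)N2c2ccc(N3CCN(Cc4ccc(Cl)c(Cl)c4)CC3)cn2)c(OC)c1` differs from compound 2 by 3,4-dichlorobenzyl in place of (4-fluorophenyl)sulfonyl on an amine nitrogen in a ring, which largely undoes that step, since a benzyl group again replaces the sulfonyl. Compound 3 is therefore expected to show a modest step downward, a 2.4-fold lower number from compound 2 to compound 3 (0.39 log units; beyond the scatter), landing close to compound 1, and its estimated value is 32000 nM with a range from 12000 nM to 80000 nM.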

Compound 3, half-maximal inhibitory concentration: 61000 nM
Compound 3: middle estimate off by 1.9-fold (0.28 log units), on the low side; low and high end bracket the measured number.
By their numbers in this assay, from the lowest: compounds 1, 3 and 2 (each within the scatter of the next, the first and the last beyond it).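

In this assay the step of a 1.3-fold lower number from compound 2 to compound 3 (0.11 log units; within the scatter) shows that, on this amine nitrogen in a ring, 3,4-dichlorobenzyl does not separate from (4-fluorophenyl)sulfonyl, so the earlier gap does not hold for every benzyl group. The change on the benzyl ring, with a 1.6-fold higher number from compound 1 to compound 3 (0.21 log units; within the scatter) as its step, also stays within the scatter. No supporting data bear on why these numbers fall as they do. Going by these compounds, whether an acetyl group on this nitrogen, or an amine or carboxylic acid on the benzyl ring, would give a clearly different number stays open.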